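Fluoro for Chloro in a Rice Inhibition Series

The source may hold more compounds than are shown below. What is called first, only, known or untested is meant among the compounds shown, and "the series" means these compounds.

Of the compounds shown here, three have been measured in an ADME assay on the whole organism for inhibition, with Oryza sativa as the target, with a stated time of 7 days; on this read-out higher numbers stand for weaker inhibition and lower numbers for stronger inhibition. Compound 1 `CCCCC(=O)ON1C(=O)COc2ccc(Cl)cc21` gives 2000 nM. Compound 3 `O=C1C(c2ccccc2)Oc2ccc(Cl)cc2N1O` gives 992000 nM, and compound 2 `O=C1C(c2ccccc2)Oc2ccc(F)cc2N1O` gives 1240000 nM. The difference between the core of compound 1 and the core of compound 3 is not broken down here; their two values simply stand far apart. From compound 3 to compound 2 the change is fluoro in place of chloro on an aromatic carbon, and the step is a 1.3-fold higher number from compound 3 to compound 2 (0.10 log units; within the scatter). Compound 4 `CCCCC(=O)ON1C(=O)COc2ccc(F)cc21`, still unmeasured, carries the same change relative to compound 1: fluoro in place of chloro on an aromatic carbon. Among the measured compounds shown here, because the only earlier example of this change gave a 1.3-fold higher number from compound 3 to compound 2 (0.10 log units; within the scatter), the step from compound 1 to compound 4 is expected to be small, a 1.2-fold higher number from compound 1 to compound 4 (0.08 log units; within the scatter), an expectation resting on that single pair alone. Compound 4 is therefore estimated at 2400 nM, with a likely range from 900 nM to 6500 nM.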

Compound 4, half-maximal inhibitory concentration: 6000 nM
The estimate for compound 4 lay 2.5-fold (0.40 log units) below the measured number; low and high end bracket the measured number.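

In this assay, fluoro in place of chloro on an aromatic carbon gave a 3.0-fold higher number from compound 1 to compound 4 (0.48 log units; beyond the scatter). Set beside the earlier example, the two cores cannot be told apart for this change: the same change on two cores in this assay, a 1.3-fold higher number (0.10 log units; within the scatter) from compound 3 to compound 2 and a 3.0-fold higher number (0.48 log units; beyond the scatter) from compound 1 to compound 4, 2.4-fold (0.38 log units) apart, within the scatter of two such steps. Among the compounds shown here, the change therefore carried across these two cores about equally, but two pairs set no rule for any other core, and they do not show why only the step on the core of compound 1 lies beyond the scatter when read alone.

Still open, on these data alone, is how the number would respond to bromo or a methoxy group on that aromatic carbon. Also open, as far as these compounds go, is the effect of a longer chain on the ester of compound 1, or of a carboxylic acid in its place.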